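The source may hold more compounds than are shown below. What is called first, only, known or untested is meant among the compounds shown, and "the series" means these compounds.

Values so far in a functional assay on HCT-116 cells (Homo sapiens) for cytotoxicity, read by MTT assay, with a stated time of 72 h (on this read-out lower numbers stand for stronger inhibition and higher numbers for weaker inhibition), for the series:
- compound 1 (`COc1ccc(/C=C/c2cc(C)n[nH]2)cc1`) gives 9400 nM
- compound 2 (`Cc1cc(/C=C/c2ccc(O)c(O)c2)on1`) gives 5300 nM
- compound 3 (`COc1ccc(/C=C/c2cc(C)n[nH]2)cc1OC`) gives 51300 nM

Compound 2 stands level with compound 1, their two values lying within the scatter of each other. Compound 3 has a higher number than compound 2, and that gap is beyond the scatter.

Compound 4 (`COc1cc(/C=C/c2cc(C)no2)ccc1O`) is not yet measured. It departs from compound 2 by one change (methyl in place of hydrogen on an oxygen on an aromatic ring), with methyl in place of hydrogen on an oxygen on an aromatic ring, which reads as hydroxy to methoxy.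

For the measured compounds named here, no measured step makes this same change. Going by the values given here, the closest is the one ending at compound 3 (a 5.5-fold higher number from compound 1 to compound 3 (0.74 log units; beyond the scatter)), where methoxy takes the place of hydrogen on an aromatic carbon. It is a modest step, it sits on the core of compound 1, and it is a single example, so it bears only loosely on compound 4. Going by compound 3 and that step, a smaller move to a higher number is expected in this assay for this change. The estimated step is a 2.1-fold higher number from compound 2 to compound 4 (0.32 log units; beyond the scatter) on that reading. For compound 4 the estimated value is 11000 nM with an expected range from 3500 nM to 35000 nM in this series.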

Compound 4, half-maximal inhibitory concentration: 33400 nM
Estimate against measurement, compound 4: 3.0-fold (0.48 log units) below, within the range that was stated.
By their numbers in this assay, from the lowest: compounds 2 and 1 (each within the scatter of the next); then compounds 4 and 3 (each within the scatter of the next).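

In this assay, for the compounds shown here, the step for hydroxy to methoxy is a 6.3-fold higher number from compound 2 to compound 4 (0.80 log units; beyond the scatter) and gives the first reading of a change made on an oxygen on an aromatic ring, on the core of compound 2. Going by these compounds alone, the only earlier step, a 5.5-fold higher number from compound 1 to compound 3 (0.74 log units; beyond the scatter) on the core of compound 1, placed methoxy on an aromatic carbon and so said nothing directly about replacing the hydrogen of a hydroxy group. Both single steps now run to a higher number beyond the scatter, one on each core, and compound 4 shows that methyl in place of this hydrogen is not tolerated without loss in this series, although one hydroxy remains.

The compounds shown leave open whether the same change at the other hydroxy of compound 2 gives a step of similar size, and whether a hydroxy group on the core of compound 1 would behave as it does on the core of compound 2. They also leave open how an ethoxy group, an amine or a carboxylic acid would read at this place, and no measurement at hand explains the size of the step.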